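Sulfonyl aryl exchange on the lactam sulfonamide series

The source may hold more compounds than are shown below. What is called first, only, known or untested is meant among the compounds shown, and "the series" means these compounds.

Compound 3 `O=C1[C@@H](NS(=O)(=O)c2cc3c(Cl)nccc3s2)CCN1Cc1cc2c[nH]ccc-2n1` stands second highest of the three numbers in hand for an assay on isolated protein for inhibition of coagulation factor X (Oryctolagus cuniculus), tested at 1 uM; a higher number here means more inhibition at the concentration tested (going by the name of the read-out), a lower number less inhibition; in this assay compound 3 gives 35%. Compound 1 `O=C1[C@@H](NS(=O)(=O)c2cc3ncccc3s2)CCN1Cc1cc2c[nH]ccc-2n1` sits above it, and in this assay compound 1 gives 61%; the step of a number 26 percentage points lower from compound 1 to compound 3 (beyond the scatter) lies beyond the scatter. Compound 2 `O=C1[C@@H](NS(=O)(=O)c2nc3cc(Cl)ccc3[nH]2)CCN1Cc1cc2cc[nH]cc-2n1` sits below compound 3 by a margin beyond the scatter, and in this assay compound 2 gives 21%.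

Compound 4 `O=C1[C@@H](NS(=O)(=O)c2nc3cc(Cl)ccc3[nH]2)CCN1Cc1cc2c[nH]ccc-2n1` is not yet measured. a group of 10 heavy atoms (7 carbon, 2 nitrogen, 1 chlorine; one five-membered aromatic ring with 2 hetero atoms, one six-membered aromatic ring of carbon only) in place of a group of 10 heavy atoms (7 carbon, 1 nitrogen, 1 sulfur, 1 chlorine; one five-membered aromatic ring with 1 hetero atom, one six-membered aromatic ring with 1 hetero atom), on a sulfonyl sulfur The 5-chloro-1H-benzimidazol-2-yl group thus enters on the sulfonyl sulfur whose other neighbour is the sulfonamide nitrogen.

Among the measured compounds shown here, no measured step matches this exchange directly. For the measured compounds named here, the single step in hand, a number 26 percentage points lower from compound 1 to compound 3 (beyond the scatter), only adds a chlorine to the group that leaves here. Compound 2 carries the same entering group on a differently arranged core and gives 21%, the lowest of the three values. Compound 3 is therefore expected to lose inhibition on passing to compound 4, with the expected step of a number 10 percentage points lower from compound 3 to compound 4 (within the scatter) beyond the scatter and downward. Compound 4 is estimated at 25%, with a range from 10% to 42%.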

Compound 4, a percentage reported as inhibition, at one concentration (the size of the read-out at that concentration, not a potency): 31%
Compound 4: middle estimate off by 6 percentage points, on the low side; measured number inside the range.
By their numbers in this assay, from the lowest: compounds 2, 4 and 3 (each within the scatter of the next, the first and the last beyond it); then compound 1.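

In this assay, the 5-chloro-1H-benzimidazol-2-yl group on the sulfonyl sulfur cannot be told apart from the chlorine-bearing group it replaces (a number 4 percentage points lower from compound 3 to compound 4 (within the scatter)), so this exchange of one chlorinated group for the other leaves the read-out unchanged within the scatter. Among the compounds shown here, both chlorine-bearing groups fall short of the chlorine-free group of compound 1 (a number 26 percentage points lower from compound 1 to compound 3 (beyond the scatter); a number 30 percentage points lower from compound 1 to compound 4 (beyond the scatter)), which now makes compound 1 the only member of the set standing clear of all the others. The change on the saturated chain carbon bound to an amide-type nitrogen in a ring also stays within the scatter (a number 10 percentage points higher from compound 2 to compound 4 (within the scatter)), and compound 4 now links compound 2 and compound 3, which differ in two places, through two steps that are each within the scatter.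

Nothing in hand explains any of these steps. Still open, going by these compounds, is how much of the gap to compound 1 goes with the chlorine itself, since the benzimidazole group appears here only with chlorine, and whether a methyl, a methoxy or a carboxylic acid at the place of that chlorine would hold the read-out of compound 1.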